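The compounds below may be only part of what the source reports. "The series", "measured", "known", "first", "only" and "open" are said of these compounds alone.

Compound 1 `CC1C(=O)CC(c2ccc(F)cc2)N(C(=O)CN2CCN(C)CC2)C1c1ccc(Cl)cc1` gives 2.09 in a physicochemical assay for lipophilicity, using the shake flask method; a higher number here means a more lipophilic compound, a lower number a more polar compound.
Compound 2 `CC1C(=O)CC(c2ccc(F)cc2)N(C(=O)CCl)C1c1ccc(Cl)cc1` gives 1.72.
Compound 3 `COc1ccc(C2C(C)C(=O)CC(c3ccc(Cl)cc3)N2C(=O)CCl)cc1` gives 1.29.

Compound 3 thus stands lowest of the three measured compounds, with compound 2 nearer to it and compound 1 furthest away. Compound 4 `CC1C(=O)CC(c2ccc(Cl)cc2)N(C(=O)CCl)C1c1ccc(N(C)C)cc1` differs from compound 3 in one place: dimethylamino in place of methoxy on an aromatic carbon. Among the measured compounds shown here, the only measured step, a number 0.37 log units lower from compound 1 to compound 2 (beyond the scatter), concerns a different group at a different place, so it does not bear directly on this change, and nothing measured here tells how exchanging methoxy for dimethylamino shifts the number. The step expected from compound 3 to compound 4 is a number 0.21 log units higher from compound 3 to compound 4 (within the scatter), a small rise that need not exceed the scatter. Compound 4 is therefore estimated at 1.5, with a likely range from 1.15 to 1.85.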

Compound 4, partition coefficient: 1.24
For compound 4 the middle estimate is 0.26 log units above the measured one; the measured number falls inside the stated range.
By their numbers in this assay, from the lowest: compounds 4 and 3 (each within the scatter of the next); then compound 2; then compound 1.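

In this assay, dimethylamino in place of methoxy on this aromatic carbon, para to a large group, gives a number 0.05 log units lower from compound 3 to compound 4 (within the scatter). At this position, then, the two groups cannot be told apart by this read-out, a point the earlier step, made at a different place, could not settle. Nothing at hand offers a reason for this result.

Still open, as far as these compounds go, is how the number would respond to a carboxylic acid or a longer chain such as butoxy at this position. From the compounds shown here alone, whether the same exchange reads alike elsewhere on the shared core also remains open.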